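The source may hold more compounds than are shown below. What is called first, only, known or untested is meant among the compounds shown, and "the series" means these compounds.

Measured so far in a functional assay on Jurkat cells for inhibition of nuclear factor NF-kappa-B complex (Homo sapiens); on this read-out higher numbers stand for weaker inhibition and lower numbers for stronger inhibition:
- compound 1 `CCOC(=O)c1cnc(-c2cnc3ccccc3c2)nc1NN1C(=O)C=C(C)C1=O`: 6000 nM
- compound 2 `CCOC(=O)c1cnc(-n2nc(C)cc2C)nc1NN1C(=O)C=C(C)C1=O`: 10000 nM
- compound 3 `CCOC(=O)c1cnc(-c2ccc(F)cc2)nc1NN1C(=O)C=C(C)C1=O`: 700 nM

Compound 3 gives the lowest number of the three. Its nearest neighbour is compound 1, an 8.6-fold lower number from compound 1 to compound 3 (0.93 log units; beyond the scatter), and the furthest is compound 2, a 14-fold lower number from compound 2 to compound 3 (1.15 log units; beyond the scatter). Compound 1 and compound 2 are separated by a 1.7-fold higher number from compound 1 to compound 2 (0.22 log units; within the scatter).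

Compound 4 `CCOC(=O)c1cnc(CC2=CCCCC2)nc1NN1C(=O)C=C(C)C1=O` has not yet been measured. It differs from compound 3 at one place: (cyclohex-1-en-1-yl)methyl in place of 4-fluorophenyl on an aromatic carbon.

The two steps that touch this place, an 8.6-fold lower number from compound 1 to compound 3 (0.93 log units; beyond the scatter) and a 14-fold lower number from compound 2 to compound 3 (1.15 log units; beyond the scatter), both exchange one aromatic group for another and both end at compound 3. Within the data shown here, neither step puts a non-aromatic group at this place, so there is no direct precedent. Given that the three measured groups span a considerable range and compound 3 sits at its strongest end, compound 4 is expected to give a higher number, estimated at 3000 nM in this assay, between 700 nM and 15000 nM, which would mean an expected step of a 4.3-fold higher number from compound 3 to compound 4 (0.63 log units; beyond the scatter).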

Compound 4, half-maximal inhibitory concentration: 2000 nM
Beside the measured number, compound 4's estimate is 1.5-fold (0.18 log units) above it; the range from low to high includes it.
By their numbers in this assay, from the lowest: compound 3; then compound 4; then compounds 1 and 2 (each within the scatter of the next).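

Placing the non-aromatic (cyclohex-1-en-1-yl)methyl on this aromatic carbon between two ring nitrogen atoms in this assay gives a 2.9-fold higher number from compound 3 to compound 4 (0.46 log units; beyond the scatter) and so gives up only part of the low number seen with 4-fluorophenyl. The same group gives a 3.0-fold lower number from compound 1 to compound 4 (0.48 log units; beyond the scatter) and a 5.0-fold lower number from compound 2 to compound 4 (0.70 log units; beyond the scatter) against quinolin-3-yl and 3,5-dimethyl-1H-pyrazol-1-yl. An aromatic group at this place is therefore not needed for a number below those of compound 1 and compound 2, although compound 3, with its 4-fluorophenyl, still gives the lowest number of the four.

The change to compound 4 alters both the ring and its methyl link, and the compounds shown do not separate the two, as a benzyl group could. No measurement is available that explains this order.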